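Cytotoxicity of a Shared Core with Varied Side Groups

The source may hold more compounds than are shown below. What is called first, only, known or untested is meant among the compounds shown, and "the series" means these compounds.

Measured compounds:
- compound 1, `Cc1cc(C)c(Oc2cc(Nc3ccc(C#N)cc3)ncc2C(=O)NCc2cn(CC(N)=O)nn2)c(C)c1`: 24000 nM
- compound 2, `CC(=O)Cn1cc(CNC(=O)c2cnc(Nc3ccc(C#N)cc3)cc2Oc2c(C)cc(C)cc2C)nn1`: 19400 nM
- compound 3, `CCOC(=O)CCn1cc(CNC(=O)c2cnc(Nc3ccc(C#N)cc3)cc2Oc2c(C)cc(C)cc2C)nn1`: 21500 nM

All three values come from an ADME assay on MT4 cells (Homo sapiens) for cytotoxicity, read by MTT assay, with a stated time of 5 days; on this read-out higher numbers stand for lower toxicity in this test and lower numbers for higher toxicity in this test. Compound 3 sits second highest of the three numbers; its nearest neighbour is compound 2, a 1.1-fold higher number from compound 2 to compound 3 (0.04 log units; within the scatter), and its furthest is compound 1, a 1.1-fold lower number from compound 1 to compound 3 (0.05 log units; within the scatter). Both gaps are within the scatter, so the three compounds are indistinguishable on this read-out.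

Compound 4, `Cc1cc(C)c(Oc2cc(Nc3ccc(C#N)cc3)ncc2C(=O)NCc2cn(Cc3cccc(C#N)c3)nn2)c(C)c1`, differs from compound 3 in one place: 3-cyanophenyl in place of (ethoxycarbonyl)methyl on a saturated chain carbon bound to an aromatic nitrogen.

Within the data shown here, no measured step introduces an aromatic ring at this position, so none bears directly on the change. The steps that do exist at this place, a 1.2-fold lower number from compound 1 to compound 2 (0.09 log units; within the scatter) and a 1.1-fold higher number from compound 2 to compound 3 (0.04 log units; within the scatter), show that swapping one small group for another here left the number within the scatter. On that basis no step beyond the scatter is expected, and the step is estimated as a 1.1-fold lower number from compound 3 to compound 4 (0.03 log units; within the scatter). Compound 4 is therefore expected to give 20000 nM, with a range from 8000 nM to 50000 nM.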

Compound 4, half-maximal cytotoxic concentration: >= 129000 nM
Compound 4 ended at the assay's limit (the forecaster's own chance of this, stated with the estimate: 20%); middle value at least 6.4-fold (0.80 log units) from the limit.
By their numbers in this assay, from the lowest: compounds 2, 3 and 1 (each within the scatter of the next). At a limit, above all of these: compound 4.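

In this assay, among these compounds, the place on a saturated chain carbon bound to an aromatic nitrogen proves able to move the number, something the earlier compounds, all within the scatter of each other, gave no sign of. Putting 3-cyanophenyl in place of (ethoxycarbonyl)methyl gives an at least 6.0-fold higher number from compound 3 to compound 4 (0.77 log units; beyond the scatter), and the same kind of change from the other two side groups gives an at least 6.6-fold higher number from compound 2 to compound 4 (0.82 log units; beyond the scatter) and an at least 5.3-fold higher number from compound 1 to compound 4 (0.73 log units; beyond the scatter), so compound 4, the only one of these with an aromatic ring in its side group, stands apart from all three and reads as less toxic in this test. The number for compound 4 is a limit of the assay and not an exact value, so its true distance from the others stays unknown: the limit of >= 129000 nM in this assay, at which 1 of the 4 values shown sits.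

Whether the aromatic ring alone or the nitrile on it accounts for this shift stays open, and a plain benzyl group in place of 3-cyanobenzyl would separate the two. Also open, from the compounds shown here alone, is whether an amine or a carboxylic acid on the same chain would stay with compounds 1, 2 and 3 or move as far as compound 4.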